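From chloro to ((dichloromethyl)carbonyl)amino in a cytotoxicity test

The source may hold more compounds than are shown below. What is called first, only, known or untested is meant among the compounds shown, and "the series" means these compounds.

Measured in a functional assay on KB 3-1 cells (Homo sapiens) for cytotoxicity, read by MTT assay, with a stated time of 68 h; a higher number here means a weaker inhibitor, a lower number a stronger inhibitor:
- compound 1 `Cc1cccc(-c2cccc(NC(=O)C(Cl)Cl)c2)c1`: > 50000 nM
- compound 2 `O=C(Nc1cccc(-c2cccc(Cl)c2)c1)C(Cl)Cl`: > 50000 nM

Each of these entries is a limit of the assay and not a number. Compound 2 therefore stands at > 50000 nM in this assay, a limit that gives no exact strength. The overall picture so far is the limit of > 50000 nM in this assay, at which 2 of the 2 values shown sit.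

Compound 3 `O=C(Nc1cccc(-c2cccc(NC(=O)C(Cl)Cl)c2)c1)C(Cl)Cl` differs from compound 2 in one place: ((dichloromethyl)carbonyl)amino in place of chloro on an aromatic carbon. Going by the values given here, the only measured step that bears on this change is a step that the two limits leave unreadable from compound 1 to compound 2. Among the compounds with values here, it gives no size to carry over, and no measured compound has this group in this place. A large gain in strength is therefore not expected, though a modest one remains possible. The expected change is an at least 1.2-fold lower number from compound 2 to compound 3 (0.09 log units; that floor lies within the scatter). For compound 3 the estimated value is 40000 nM, within an expected range of 10000 nM to 60000 nM.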

Compound 3, half-maximal inhibitory concentration: > 50000 nM
Compound 3 ended at the assay's limit; the forecaster's own chance of this, stated with the estimate: 60%; middle value at least 1.2-fold (0.09 log units) away from the limit.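

In this assay compound 3 gives > 50000 nM, a limit of the assay and not a number. The steps among compound 1, compound 2 and compound 3 therefore cannot be read. The compounds shown leave open how strong each one is, and whether methyl, chloro or ((dichloromethyl)carbonyl)amino changes strength at all.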